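Aryl substituent variation on the shared core toward compound 4

The compounds below may be only part of what the source reports. "The series", "measured", "known", "first", "only" and "open" are said of these compounds alone.

Measured compounds and their numbers in an assay on FRT-Jurkat cells for inhibition of nuclear factor NF-kappa-B complex (Homo sapiens), read by flow cytometry, with a stated time of 24 h, tested at 10 uM; a higher number here means more inhibition at the concentration tested (going by the name of the read-out), a lower number less inhibition:
compound 1 `C=C(OCC)c1ccc(Nc2cccc3c2C(=O)N(C2CCC(=O)NC2=O)C3=O)cc1` gives 10%
compound 2 `CCCc1ccc(Nc2ccc3c(c2)C(=O)N(C2CCC(=O)NC2=O)C3=O)cc1` gives 10%
compound 3 `Cc1ccc(Nc2cccc3c2C(=O)N(C2CCC(=O)NC2=O)C3=O)cc1` gives 9%

All three numbers sit close together. Compound 3 shows the smallest of the three in this assay, but its gaps to compound 1 and to compound 2 are within the scatter, so no ordering among them can be claimed. Among the compounds with values here, the only single-place step among the measured compounds runs a number 1 percentage points lower from compound 1 to compound 3 (within the scatter), a change that moved nothing beyond the scatter.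

Compound 4 `CC(C)c1ccc(Nc2cccc3c2C(=O)N(C2CCC(=O)NC2=O)C3=O)cc1` is the next member. Relative to compound 3 the change is isopropyl in place of methyl on an aromatic carbon. Within the data shown here, no measured step involves isopropyl, and the one step that does bear on this position of the aromatic ring, a number 1 percentage points lower from compound 1 to compound 3 (within the scatter), shows a group exchange at the same place leaving this assay unchanged within the scatter. Compound 2, carrying propyl on the same aryl ring but with a different attachment of the core, also gives a number in the same band as compound 3. Nothing in the data points to a shift in either direction beyond the scatter.

Compound 4 is therefore expected to give 10% in this assay, with a range of 0% to 22%, meaning an expected step of a number 1 percentage points higher from compound 3 to compound 4 (within the scatter).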

Compound 4, a percentage reported as inhibition, at one concentration (the size of the read-out at that concentration, not a potency): 19%
Beside the measured number, compound 4's estimate is 9 percentage points below it; the range from low to high includes it.
By their numbers in this assay, from the lowest: compounds 3, 1, 2 and 4 (each within the scatter of the next).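

In this assay, isopropyl in place of methyl on the aromatic carbon para to a large group gives a number 10 percentage points higher from compound 3 to compound 4 (within the scatter), and isopropyl in place of 1-ethoxyethenyl at the same place gives a number 9 percentage points higher from compound 1 to compound 4 (within the scatter). Both steps stay within the scatter, so neither the 4-methylphenyl to 4-isopropylphenyl change nor the exchange with 1-ethoxyethenyl can be claimed to alter inhibition, and methyl, isopropyl and 1-ethoxyethenyl cannot be ordered at this position. No supporting data bear on these steps, so the result stands without an explanation.

Still open, on these data alone, is whether an amine, a carboxylic acid or a longer chain such as butyl at this place on the shared core would move the number in this assay beyond the scatter, in either direction. Within the data shown here, these readings also come from a single concentration, so they give no potency for any compound, and they cannot show whether the small differences seen here would widen over a range of concentrations.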